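Methylating the oxime hydroxy on two cores

The source may report more compounds than this note shows. Statements on the series, on what has been measured and on what is new or still open speak of the compounds shown alone.

Compound 1 `O=c1c(OC/C(=N/O)c2ccc(F)cc2)c(-c2ccccc2)oc2ccccc12` and compound 3 `CO/N=C(/COc1c(-c2ccccc2)oc2ccccc2c1=O)c1ccc(F)cc1` share one core and differ only by methyl in place of hydrogen on an oxygen. Going by the values given here, in a functional assay on SK-HEP1 cells (Homo sapiens) for antiproliferative activity (on this read-out higher numbers stand for weaker inhibition of growth and lower numbers for stronger inhibition of growth), compound 1 gives 6900000 nM, while compound 3 gives 13000000 nM; the step of a 1.9-fold higher number from compound 1 to compound 3 (0.28 log units; within the scatter) is the single measured instance of this change, and it lies within the scatter of this assay.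

Compound 2 `O=c1cc(-c2ccccc2)oc2cc(OC/C(=N/O)c3ccccc3)ccc12` carries the same oxime side chain on a second core; how the core of compound 2 differs from the core of compound 1 is not broken down here. In this assay compound 2 gives 2000000 nM, the lowest of the three numbers, and its steps to compound 1 and to compound 3 are both beyond the scatter.

Compound 4 `CO/N=C(/COc1ccc2c(=O)cc(-c3ccccc3)oc2c1)c1ccccc1` is not yet measured and differs from compound 2 by methyl in place of hydrogen on an oxygen. This is the same change as from compound 1 to compound 3, at the same place, an oxygen whose other neighbour is a double-bonded nitrogen. With one measured instance only, the expectation for compound 4 rests on that step alone: in this assay a step of a 1.9-fold higher number from compound 2 to compound 4 (0.28 log units; within the scatter) is expected, set beside a 1.9-fold higher number from compound 1 to compound 3 (0.28 log units; within the scatter). Compound 4 is therefore estimated at about 3800000 nM in this assay, with a range from 1500000 nM to 10000000 nM expected to cover most repeat measurements.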

Compound 4, concentration for 50% growth inhibition: 2000000 nM
For compound 4 the middle estimate is 1.9-fold (0.28 log units) above the measured one; measured number inside the range.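

In this assay, methyl in place of hydrogen on the oxime oxygen gives no change at the digits printed from compound 2 to compound 4 (within the scatter), and the two instances of this change can be set side by side: the same change on two cores in this assay, a 1.9-fold higher number (0.28 log units; within the scatter) from compound 1 to compound 3 and no change at the digits printed (within the scatter) from compound 2 to compound 4, 1.9-fold (0.28 log units) apart, within the scatter of two such steps

Read together, the two pairs show that hydroxy to methoxy on this oxime side chain gives a step within the scatter on both cores, and that the step on one core does not differ measurably from the step on the other. Going by these compounds alone, this does not show that the change is without consequence in general: there are only two pairs, they come from a single cell assay, and they differ in more than the core, since compound 1 and compound 3 carry a fluorine that compound 2 and compound 4 lack.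

The compounds shown leave open whether a larger group on the same oxygen, such as an ethyl group, a longer chain or a chain ending in an amine or a carboxylic acid, would give a step beyond the scatter. They also leave open whether the oxime's nitrogen-oxygen unit is needed at all, as no side chain ending in a plain ketone or an amide stands among them.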